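Cinnamamides and a cinnamate ester against Brassica rapa

This account rests on a few compounds, and the source may have more. Where it says the series, first, only, none or still open, it means among the compounds named here.

Three cinnamamides have been measured in a functional assay on the whole organism for inhibition, with Brassica rapa subsp. chinensis as the target, with a stated time of 3 days, tested at 100 ppm; a higher number here means more inhibition of growth at the concentration tested, a lower number less inhibition of growth. Compound 1 `CC(C)(C)NC(=O)/C=C/c1ccccc1` gives 34%, compound 2 `CCC(C)NC(=O)/C=C/c1ccccc1` gives 56%, and compound 3 `C=CCNC(=O)/C=C/c1ccccc1` gives 63%, the highest of the three numbers. The steps of a number 22 percentage points higher from compound 1 to compound 2 (beyond the scatter) and a number 29 percentage points higher from compound 1 to compound 3 (beyond the scatter) lie beyond the scatter, whereas a number 7 percentage points higher from compound 2 to compound 3 (within the scatter) does not.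

Compound 4 `CCCCOC(=O)/C=C/c1ccccc1` differs from compound 3 in one place: butoxy in place of allylamino on a carbonyl carbon. For the measured compounds named here, every measured step exchanges one group on the amide-type nitrogen; none touches the amide itself, so no measured step bears on this change, and the expectation rests on nothing firmer than the spread of the three numbers. Compound 4 is therefore estimated at 45%, within 15% to 75%, in this assay, which would mean an expected step of a number 18 percentage points lower from compound 3 to compound 4 (beyond the scatter).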

Compound 4, percent growth inhibition at one concentration: 5%
Estimate against measurement, compound 4: 40 percentage points above; the whole stated range lies above it.
By their numbers in this assay, from the lowest: compound 4; then compound 1; then compounds 2 and 3 (each within the scatter of the next).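

Exchanging allylamino for butoxy on the carbonyl carbon in this assay gives a number 58 percentage points lower from compound 3 to compound 4 (beyond the scatter), and the matching exchanges give a number 51 percentage points lower from compound 2 to compound 4 (beyond the scatter) and a number 29 percentage points lower from compound 1 to compound 4 (beyond the scatter). The earlier compounds shown here showed only changes to the group on the nitrogen, whereas these steps show that replacing the whole amino group with butoxy lowers the number from each of the three amides, including compound 1, which has the lowest number among them. No measurement shown accounts for this drop. Since nitrogen and chain change together, the compounds shown leave open whether butylamino on the same carbonyl carbon would match the amides, and whether a methoxy ester would match compound 4.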